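Changing the Aryl Group on the Amine of Compound 1

The compounds below may be only part of what the source reports. "The series", "measured", "known", "first", "only" and "open" are said of these compounds alone.

Measured compounds:
compound 1, `C=C1[C@@H](OC(C)=O)C[C@@H]2[C@](C)(CO[Si](C)(C)C(C)(C)C)[C@H](OC(C)=O)CC[C@@]2(C)[C@@H]1C[C@@H](Nc1ccc(C(=O)O)cc1)C1=CCOC1=O`: 5540 nM
compound 2, `C=C1[C@@H](OC(C)=O)C[C@@H]2[C@](C)(COC=O)[C@H](OC(C)=O)CC[C@@]2(C)[C@@H]1C[C@@H](Nc1ccc(C(=O)O)cc1)C1=CCOC1=O`: > 50000 nM

Among the measured compounds shown here, in a functional assay on KB cells (Homo sapiens) for cytotoxicity, read by sulforhodamine B assay (a higher number here means a weaker inhibitor, a lower number a stronger inhibitor), compound 1 gives 5540 nM, the only number recorded here. For compound 2 the reading is a limit of this assay, > 50000 nM. Compound 3, `C=C1[C@@H](OC(C)=O)C[C@@H]2[C@](C)(CO[Si](C)(C)C(C)(C)C)[C@H](OC(C)=O)CC[C@@]2(C)[C@@H]1C[C@@H](Nc1cccc(OC)c1)C1=CCOC1=O`, differs from compound 1 by 3-methoxyphenyl in place of 4-carboxyphenyl on an amine nitrogen. For the measured compounds named here, the one measured step, an at least 9.0-fold higher number from compound 1 to compound 2 (0.95 log units; beyond the scatter), alters a different part of the molecule and therefore does not bear on this change. With nothing to guide direction, compound 3 is expected to land near compound 1, with a wide range: 5500 nM, between 1000 nM and 30000 nM. This estimate means a step of a 1.0-fold lower number from compound 1 to compound 3 (0.00 log units; within the scatter).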

Compound 3, half-maximal inhibitory concentration: 45200 nM
Estimate against measurement, compound 3: 8.2-fold (0.91 log units) below; measured number outside the range, above it.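

Replacing 4-carboxyphenyl with 3-methoxyphenyl on the amine nitrogen brings an 8.2-fold higher number from compound 1 to compound 3 (0.91 log units; beyond the scatter) in this assay. The aryl group on this nitrogen therefore affects the reading, as the silyl-bearing end changed in the earlier step also did. Compound 2 stands at a limit of the assay, and compound 3 now reads not far short of it: the limit of > 50000 nM in this assay, at which 1 of the 3 values shown sits.

This step changes both the substituent and its place on the ring, so the two effects cannot be separated. From the compounds shown here alone, how 3-carboxyphenyl, 4-methoxyphenyl or unsubstituted phenyl on this nitrogen would read remains open.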